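Aryl amide in place of acetyl on the ring nitrogen

A few compounds are considered here, and "the series" means these few. Any claim that something is new, unique, unknown or untested is made for them only; others in the source may bear on it.

Measured so far:
compound 1, `CC(=O)N1c2ccccc2CCC1C(=O)Nc1cc(C(F)(F)F)cc(C(F)(F)F)c1` — > 70000 nM
compound 2, `COc1ccc(NC(=O)C2CCc3ccccc3N2)cc1` — 51900 nM

In a functional assay on NUGC-3 cells (Homo sapiens) for cytotoxicity, read by sulforhodamine B assay, with a stated time of 72 h (a higher number here means a weaker inhibitor of growth, a lower number a stronger inhibitor of growth), compound 1 reaches only a limit of the assay, > 70000 nM, and no number is known for it. This is recorded as the limit of > 70000 nM in this assay, at which 1 of the 2 values shown sits. Among the measured compounds shown here, compound 2, which shares the core but carries no group on the ring nitrogen and a methoxyphenyl amide, gives 51900 nM in this assay; as no single-point step joins compound 2 to compound 1, nothing more is drawn from the pair than these two values.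

Compound 3, `O=C(Nc1cc(C(F)(F)F)cc(C(F)(F)F)c1)C1CCc2ccccc2N1C(=O)c1ccc(Cl)cc1`, differs from compound 1 in one place: 4-chlorophenyl in place of methyl on a carbonyl carbon. For the measured compounds named here, no measured step of this kind exists, so the size and direction can only be guessed. The change is a large one on the nitrogen, and the expectation is a step of moderate size toward stronger growth inhibition in this assay, with a fair chance that compound 3 again returns only a limit. The estimated step from compound 1 to compound 3 is an at least 2.0-fold lower number from compound 1 to compound 3 (0.30 log units; that floor lies within the scatter). Compound 3 is expected to give about 35000 nM in this assay, within a range from 8000 nM to 100000 nM.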

Compound 3, concentration for 50% growth inhibition: 1660 nM
The estimate for compound 3 lay 21-fold (1.32 log units) above the measured number; the measured number lies below the stated range.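

In this assay, 4-chlorophenyl in place of methyl on a carbonyl carbon bound to the amide-type nitrogen in a ring gives an at least 42-fold lower number from compound 1 to compound 3 (1.62 log units; beyond the scatter). This is the only step among the compounds shown, and it lies beyond the scatter, so the group on this carbonyl carbon clearly matters for growth inhibition in these cells. The true size of the step remains unknown, because compound 1 reaches only a limit of the assay and the step is therefore a floor: the limit of > 70000 nM in this assay, at which 1 of the 3 values shown sits.

Among the compounds shown here, the single step cannot separate the contribution of the aromatic ring from that of the chlorine, and it remains open whether a plain phenyl, a pyridine, a longer alkyl chain or a phenyl carrying an amine or a carboxylic acid would behave like 4-chlorophenyl at this place. For the compounds shown here, also open is how far the result depends on the trifluoromethyl groups of the other amide, since compound 2 differs from compound 3 in more than one place and no step joins them.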